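Swapping the amide group on compound 1

This account rests on a few compounds, and the source may have more. Where it says the series, first, only, none or still open, it means among the compounds named here.

compound 1 `CCn1cc(C(=O)Nc2cccc([N+](=O)[O-])c2)c(=O)c2cc(F)c(N3CCNC(C)C3)c(F)c21`: 2710 nM
compound 2 `CCn1cc(C(=O)Nc2ccc(OC)cc2)c(=O)c2cc(F)c(N3CCNC(C)C3)c(F)c21`: 3800 nM

Among the measured compounds shown here, in a functional assay on HCT-116 cells (Homo sapiens) for cytotoxicity, read by MTT assay (on this read-out higher numbers stand for weaker inhibition and lower numbers for stronger inhibition), compound 1 gives 2710 nM and stands level with its only measured neighbour, as the step of a 1.4-fold higher number from compound 1 to compound 2 (0.15 log units; within the scatter) shows. For the measured compounds named here, that step is the single measured change on this amide-type nitrogen, and it puts 4-methoxyphenyl in place of 3-nitrophenyl.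

The unmeasured compound 3 `CCn1cc(C(=O)NCc2ccc(OC)cc2)c(=O)c2cc(F)c(N3CCNC(C)C3)c(F)c21` differs from compound 1 as follows: 4-methoxybenzyl in place of 3-nitrophenyl on an amide-type nitrogen. So 4-methoxybenzyl takes the place of 3-nitrophenyl on the same nitrogen. Going by the values given here, no measured compound carries 4-methoxybenzyl, so the evidence is thin, and the range must stay wide. With only the small step of a 1.4-fold higher number from compound 1 to compound 2 (0.15 log units; within the scatter) as a guide, no clear shift beyond the scatter is expected in this assay. The estimated step is a 1.3-fold higher number from compound 1 to compound 3 (0.11 log units; within the scatter). Compound 3 is expected at 3500 nM, with an estimated range of 1500 nM to 8500 nM.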

Compound 3, half-maximal inhibitory concentration: 1400 nM
For compound 3 the middle estimate is 2.5-fold (0.40 log units) above the measured one; the measured number lies below the stated range.
By their numbers in this assay, from the lowest: compounds 3, 1 and 2 (each within the scatter of the next, the first and the last beyond it).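

Among the compounds shown here, on this amide-type nitrogen, the change from 4-methoxyphenyl to 4-methoxybenzyl gives the first step in this assay that clears the usual scatter, though only modestly (a 2.7-fold lower number from compound 2 to compound 3 (0.43 log units; beyond the scatter)), and this pair keeps the methoxy group while changing the group as named. Replacing 3-nitrophenyl with 4-methoxybenzyl gives a step that stays within the scatter (a 1.9-fold lower number from compound 1 to compound 3 (0.29 log units; within the scatter)), so this change cannot be read as a real difference. No measurement here accounts for either step.

On these data alone, it remains open whether an unsubstituted benzyl group or a longer chain such as 2-phenylethyl on this nitrogen would fit the same trend. The three compounds also leave open how an amine or a carboxylic acid on the benzyl ring would behave.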